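A few compounds are considered here, and "the series" means these few. Any claim that something is new, unique, unknown or untested is made for them only; others in the source may bear on it.

Measured so far:
compound 1, `Nc1cccc(-c2csc(NC(=O)CCCCCC(=O)Nc3ccccc3N)n2)c1` — > 30000 nM
compound 2, `CC(C)(C)OC(=O)Nc1cccc(-c2csc(NC(=O)CCCCCC(=O)Nc3ccccc3N)n2)c1` — 1500 nM

In an assay on isolated protein for inhibition of protein deacetylase HDAC6 (Homo sapiens), read by fluorescence, with a stated time of 17 h (on this read-out higher numbers stand for weaker inhibition and lower numbers for stronger inhibition), compound 1 gives no number but only a limit, > 30000 nM. Compound 2 gives 1500 nM in this assay, and that is the only number shown. Going by the values given here, the single measured step is an at least 20-fold lower number from compound 1 to compound 2 (1.30 log units; beyond the scatter), and the size of this step rests on (the limit of > 30000 nM in this assay, at which 1 of the 2 values shown sits), so its true extent is not known.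

Compound 3, `CCOC(=O)Nc1cccc(-c2csc(NC(=O)CCCCCC(=O)Nc3ccccc3N)n2)c1`, differs from compound 2 by ethyl in place of tert-butyl on an oxygen next to a carbonyl group. The carbamate that separated compound 2 from compound 1 is kept in compound 3; what changes is only the alkyl on its oxygen. The measured step from compound 1 to compound 2 therefore bears on this change only indirectly, since it concerns the presence of the carbamate rather than the size of its alkyl. Compound 3 is thus expected to land near compound 2, with a step of a 1.3-fold higher number from compound 2 to compound 3 (0.12 log units; within the scatter) that is within the scatter or at most modest in either direction. The estimate for compound 3 in this assay is 2000 nM, with a range from 600 nM to 7000 nM.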

Compound 3, half-maximal inhibitory concentration: > 30000 nM
Compound 3: no number, only a limit (the forecaster's own chance of this, stated with the estimate: 10%); at least 15-fold (1.17 log units) between middle value and limit.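

The earlier compounds shown here showed only that adding the carbamate to the free amine of compound 1 could matter; compound 3 shows that the carbamate alone is not enough in this assay, since the change on its oxygen from tert-butyl to ethyl gives an at least 20-fold higher number from compound 2 to compound 3 (1.30 log units; beyond the scatter). The requirement therefore extends to the alkyl group itself, and among these three compounds only compound 2, with tert-butyl, gives a number rather than a limit. The step between compound 1 and compound 3 cannot be read, and the true extent of the step to compound 3 is not known either: the limit of > 30000 nM in this assay, at which 2 of the 3 values shown sit.

The compounds shown leave open where along the alkyl series a measurable number returns, a question that isopropyl, cyclopropyl or benzyl on the same oxygen would address, and whether a longer chain would match tert-butyl or only a branched group would do. They also leave open whether the carbamate oxygen has any part in this, which a pivaloyl group on the same nitrogen, carrying tert-butyl directly on the carbonyl, would test.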